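The compounds below may be only part of what the source reports. "The series", "measured", "known", "first", "only" and "open" are said of these compounds alone.

Compound 1 `O=C(O)C[C@H](O)C[C@H](O)CCn1c(-c2ccc(F)cc2)nc(C(=O)NCc2ccc(F)c(F)c2)c1C1CC1` and compound 2 `Cc1c(C(=O)NCc2ccccc2)nc(-c2ccc(F)cc2)n1CC[C@@H](O)C[C@@H](O)CC(=O)O` share a core carrying an amide on one side and a dihydroxy acid chain on the other. In an assay on microsomes from liver for inhibition of 3-hydroxy-3-methylglutaryl-coenzyme A reductase (Rattus norvegicus), read by scintillation counting, with stated times of 0.5 h and 0.75 h (a higher number here means a weaker inhibitor, a lower number a stronger inhibitor), compound 1 gives 1.2 nM, and compound 2 gives 94 nM. Compound 1 therefore has the lower of the two numbers, the stronger inhibition, and the gap to compound 2 lies well beyond the scatter; since the two molecules differ in more than one place, nothing more can be read from that pair alone.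

Compound 3 `O=C(O)C[C@H](O)C[C@H](O)CCn1c(-c2ccc(F)cc2)nc(C(=O)NCc2ccccc2)c1C1CC1` is the one-point change from compound 1: phenyl in place of 3,4-difluorophenyl on a saturated chain carbon bound to an amide-type nitrogen. Within the data shown here, no measured pair shows this change by itself, so the size of the step can only be expected. Because compound 1 stands at 1.2 nM, and because compound 2, which also carries a plain benzyl group, sits at 94 nM, a moderate move towards weaker inhibition is expected, as a 2.9-fold higher number from compound 1 to compound 3 (0.46 log units; beyond the scatter), but a result within the scatter is also possible. Compound 3 is therefore estimated in this assay at 3.5 nM, with a likely range from 1 nM to 12 nM.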

Compound 3, half-maximal inhibitory concentration: 1.4 nM
Compound 3: the middle estimate sits 2.5-fold (0.40 log units) above what was measured, and the stated range covers the measured number.
By their numbers in this assay, from the lowest: compounds 1 and 3 (each within the scatter of the next); then compound 2.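

In this assay, phenyl in place of 3,4-difluorophenyl on a saturated chain carbon bound to an amide-type nitrogen gives a 1.2-fold higher number from compound 1 to compound 3 (0.07 log units; within the scatter), so at this position the two fluorine atoms make no difference that this measurement can detect, and the (3,4-difluorobenzyl)carbamoyl and benzylcarbamoyl groups cannot be told apart here. The large change lies elsewhere on the shared core: cyclopropyl in place of methyl on an aromatic carbon gives a 67-fold lower number from compound 2 to compound 3 (1.83 log units; beyond the scatter), which shows that a plain benzyl group is compatible with strong inhibition when cyclopropyl is present. Nothing measured here gives a reason for either step.

The compounds shown leave open how much more change the benzyl position accepts, for instance a single fluorine, an amine or a carboxylic acid on the phenyl ring, or a longer chain between the amide nitrogen and that ring. They also leave open whether ethyl or isopropyl on the same aromatic carbon would match cyclopropyl or stay closer to methyl.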